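Working notes on three measured analogues and one pending

The compounds below may be only part of what the source reports. "The series", "measured", "known", "first", "only" and "open" are said of these compounds alone.

Measured in an in vitro functional assay on HEK ts201 cells for antagonist activity at Neuronal acetylcholine receptor; alpha4/beta2 (Homo sapiens), read by fluorescence and calcium flux; a lower number here means a stronger inhibitor, a higher number a weaker inhibitor:
- compound 1 `CC1(C)CC(=O)N(c2ccccc2C(=O)OCC2CCCN(CCCc3ccccc3)C2)C1=O` gives 4900 nM
- compound 2 `CC1CC(=O)N(c2ccccc2C(=O)OCC2CCCN(CCCCCOc3ccccc3)C2)C1=O` gives 17000 nM
- compound 3 `O=C(CCC1CCCNC1)c1ccccc1-c1ccccc1` gives 9120 nM

Compound 2 holds the highest number of the three in this assay. Its nearest neighbour on the numbers is compound 3, whose value sits within the scatter of repeated measurement, so no order between compound 2 and compound 3 can be read from these two values. The gap to compound 1 lies beyond the scatter, and on that pair compound 1 shows the lower number. Among the compounds with values here, no pair among the three differs in a single place, so none of these gaps is tied to one structural change.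

The next compound, compound 4 `CC1CC(=O)N(c2ccccc2C(=O)OCC2CCCN(CCCCCOc3ccc(Cl)c(Cl)c3)C2)C1=O`, departs from compound 2 in one place:

3,4-dichlorophenyl in place of phenyl on an oxygen on a saturated carbon

Within the data shown here, nothing measured in the set speaks to this change; the three measured compounds give no pair that isolates it. The expectation for compound 4 therefore rests on compound 2 alone and is held close to it, with a step of a 1.9-fold lower number from compound 2 to compound 4 (0.28 log units; within the scatter) expected to stay near the scatter in this assay. Compound 4 is accordingly estimated at 9000 nM in this assay, with a range from 3000 nM to 30000 nM that allows a move in either direction.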

Compound 4, half-maximal inhibitory concentration: 17400 nM
Beside the measured number, compound 4's estimate is 1.9-fold (0.29 log units) below it, within the range that was stated.
By their numbers in this assay, from the lowest: compounds 1, 3, 2 and 4 (each within the scatter of the next, the first and the last beyond it).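

In this assay the exchange of phenyl for 3,4-dichlorophenyl on an oxygen on a saturated carbon gives a 1.0-fold higher number from compound 2 to compound 4 (0.01 log units; within the scatter) and so gives the series its first reading of a single structural change. The earlier compounds shown here could not show this, since no pair among them differed in one place; the new pair shows that this change, which adds two chlorine atoms to the ring, leaves the number within the scatter of that of compound 2. Nothing available bears on why the two numbers stand so close.

Within the data shown here, only this one exchange has been read at this position, so a single pair cannot say whether other groups on the same ring, such as a single chlorine, a methoxy group, an amine or a carboxylic acid, would leave the number equally undisturbed. Also open, from the compounds shown here alone, are a pyridine ring in place of the phenyl ring, a shorter or longer chain leading to the oxygen, and whether the same exchange would read alike on the core of compound 1.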